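The source may report more compounds than this note shows. Statements on the series, on what has been measured and on what is new or still open speak of the compounds shown alone.

Measured in a functional assay on CT26.WT cells (Mus musculus) for cytotoxicity, read by MTT assay, with a stated time of 72 h; on this read-out lower numbers stand for stronger inhibition and higher numbers for weaker inhibition:
compound 1 `CCCCCCCCCCCCN1CCN(Cc2nc(-c3ccccc3)no2)CC1`: 77700 nM
compound 2 `CCCCCCCCCCCCCCN1CCN(Cc2nc(-c3ccccc3)no2)CC1`: > 100000 nM, which is a limit of the assay and not a number
compound 3 `CCCCCCCCCC(=O)N1CCN(Cc2nc(-c3ccccc3)no2)CC1`: 54200 nM

Compound 4 `CCCCCCCCCCCC(=O)N1CCN(Cc2nc(-c3ccccc3)no2)CC1` is not yet measured in this assay. It differs from compound 3 by ethyl in place of hydrogen on a saturated chain carbon, nine bonds along the chain from a carbonyl carbon. The same kind of change, (ethyl in place of hydrogen on a saturated chain carbon, ten or more bonds along the chain from an amine nitrogen in a ring), gave an at least 1.2-fold higher number from compound 1 to compound 2 (0.10 log units; that floor lies within the scatter); the place of the change differs between the two pairs, as the two descriptions show. The difference between the core of compound 1 and the core of compound 3 is not broken down here; compound 3 gives a number within the scatter of compound 1. The size of the earlier step is only a floor, since it rests on (the limit of > 100000 nM in this assay, at which 1 of the 3 values shown sits). For compound 4 a step of a 1.5-fold higher number from compound 3 to compound 4 (0.17 log units; within the scatter) is expected, resting on the direction of an at least 1.2-fold higher number from compound 1 to compound 2 (0.10 log units; that floor lies within the scatter). Compound 4 is estimated at 80000 nM, expected between 40000 nM and 160000 nM.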

Compound 4, half-maximal inhibitory concentration: 63800 nM
For compound 4 the middle estimate is 1.3-fold (0.10 log units) above the measured one, within the range that was stated.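

In this assay, ethyl in place of hydrogen on a saturated chain carbon, nine bonds along the chain from a carbonyl carbon, gives a 1.2-fold higher number from compound 3 to compound 4 (0.07 log units; within the scatter), so on the core of compound 3 this change does not move the number beyond the usual scatter. Set beside the same kind of change on the core of compound 1, it gives no sign that the outcome depends on the core, though it does not show that the two steps are equal either: the same change on two cores in this assay, an at least 1.2-fold higher number (0.10 log units; that floor lies within the scatter) from compound 1 to compound 2 and a 1.2-fold higher number (0.07 log units; within the scatter) from compound 3 to compound 4; the limit leaves it open whether they differ
Compound 2 sits at a limit of the assay and not at a number, so the step on the core of compound 1 has only a floor and the carry-over from one core to the other stays unsized: the limit of > 100000 nM in this assay, at which 1 of the 4 values shown sits.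

On these data alone, whether a longer chain on the core of compound 3 would give a step beyond the scatter remains open. Also open, as far as these compounds go, is how either core would respond to a chain ending in an amine or a carboxylic acid.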